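Cytotoxicity notes on an anilino-heteroaryl series

A few compounds are considered here, and "the series" means these few. Any claim that something is new, unique, unknown or untested is made for them only; others in the source may bear on it.

Compound 3 `CCc1ccc(Nc2nc3ccccc3cc2-c2ccccc2)cc1` gives 73000 nM in an ADME assay on PBMC cells (Homo sapiens) for cytotoxicity, read by MTT assay, with a stated time of 72 h, in the absence of a further agent; on this read-out lower numbers stand for stronger inhibition and higher numbers for weaker inhibition. On the same read-out compound 1 `Fc1ccc(Nc2ccc3ccccc3n2)cc1` gives 90000 nM, and compound 2 `COc1ccc(Nc2cc(-c3ccc(C)cc3)ccn2)cc1` gives 52000 nM. Compound 3 thus stands second highest of the three numbers; its nearest neighbour is compound 1 and its furthest is compound 2, and both gaps lie within the usual scatter, so no order among the three can be read from these values.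

The next compound, compound 4 `COc1cccc(Nc2nc3ccccc3cc2-c2ccccc2)c1`, differs from compound 3 in one place: 3-methoxyphenyl in place of 4-ethylphenyl on a nitrogen on an aromatic ring. Within the data shown here, no step between two measured compounds in this assay has been recorded, so the size of this change has no direct precedent. All three measured numbers sit close together, which gives no basis for expecting a step beyond the scatter in either direction.

Compound 4 is expected at 65000 nM in this assay, with a range from 30000 nM to 140000 nM. The estimated step of a 1.1-fold lower number from compound 3 to compound 4 (0.05 log units; within the scatter) is expected to remain within the scatter.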

Compound 4, half-maximal inhibitory concentration: 119000 nM
Compound 4: the middle estimate sits 1.8-fold (0.26 log units) below what was measured; low and high end bracket the measured number.
By their numbers in this assay, from the lowest: compounds 2, 3, 1 and 4 (each within the scatter of the next, the first and the last beyond it).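

Among these compounds, this is the first one-place step: a 1.6-fold higher number from compound 3 to compound 4 (0.21 log units; within the scatter) in this assay. At this position, on a nitrogen on an aromatic ring, 3-methoxyphenyl in place of 4-ethylphenyl keeps the count of eight heavy atoms and brings in one hydrogen-bond acceptor, and the step stays within the scatter. No measurement available here speaks to the origin of this small step.

Going by these compounds, the step alters the group and its place on the phenyl ring together, so the effect of each alone stays open, as would a comparison of 4-methoxyphenyl with 3-methoxyphenyl. Also open, on these data alone, is whether an amine, a carboxylic acid or a longer chain on this phenyl ring would give a step beyond the scatter.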